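The source may hold more compounds than are shown below. What is called first, only, known or untested is meant among the compounds shown, and "the series" means these compounds.

In a functional assay on PC-3 cells (Homo sapiens) for cytotoxicity, with a stated time of 48 h (on this read-out higher numbers stand for weaker inhibition and lower numbers for stronger inhibition), compound 1 `Oc1ccc(-c2cncc(-c3cc4ccc(O)cc4[nH]3)n2)cc1` gives 5000 nM and compound 2 `N#Cc1ccc(-c2cncc(-c3cc4ccc(O)cc4[nH]3)n2)cc1` gives 8000 nM, which places compound 2 within the scatter of compound 1. Among the measured compounds shown here, the only measured step, cyano in place of hydroxy on an aromatic carbon, is a 1.6-fold higher number from compound 1 to compound 2 (0.20 log units; within the scatter). Compound 3 `CS(=O)(=O)c1ccc(-c2cncc(-c3cc4ccc(O)cc4[nH]3)n2)cc1` carries methylsulfonyl in place of cyano on an aromatic carbon. For the measured compounds named here, with only that one small step to go on, no shift beyond the scatter is expected in this assay, and the estimated change is a 1.1-fold lower number from compound 2 to compound 3 (0.06 log units; within the scatter). For compound 3 the estimated value is 7000 nM, with an expected range of 2500 nM to 20000 nM.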

Compound 3, half-maximal inhibitory concentration: 10000 nM
Compound 3: the middle estimate sits 1.4-fold (0.15 log units) below what was measured; the measured number falls inside the stated range.
By their numbers in this assay, from the lowest: compounds 1, 2 and 3 (each within the scatter of the next).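

Methylsulfonyl, which brings more heavy atoms than cyano and two double bonds outside aromatic rings, also stays within the scatter in this assay at this place, para to a large group: a 1.3-fold higher number from compound 2 to compound 3 (0.10 log units; within the scatter), and a 2.0-fold higher number from compound 1 to compound 3 (0.30 log units; within the scatter). Hydroxy, cyano and methylsulfonyl at this position are therefore not separated on this read-out. On these data alone, whether an amine or a carboxylic acid here would give a step beyond the scatter remains open, as does the effect of replacing the hydroxy on the shared core. No measured evidence bears on the reason for these results.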